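A few compounds are considered here, and "the series" means these few. Any claim that something is new, unique, unknown or untested is made for them only; others in the source may bear on it.

Measured so far in a functional assay on ileum for inhibition of histamine H1 receptor (Cavia porcellus); a higher number here means a weaker inhibitor, a lower number a stronger inhibitor:
Compound 1 `CCOCCn1c(N2CCN(C)CC2)nc2ccccc21` gives 10 nM.
Compound 2 `CN1CCN(c2nc3ccccc3n2CCO)CC1` gives 410 nM.
Compound 3 `CCCCN1CCCN(c2nc3ccccc3n2CCOCC)CC1` gives 8.4 nM.

Compound 2 stands at the highest of the three numbers in this assay, so it is the weakest inhibitor shown. Its neighbours both lie well below it: the step from compound 1 is a 41-fold higher number from compound 1 to compound 2 (1.61 log units; beyond the scatter), and compound 3 sits even further down. Within the data shown here, the only one-place step measured here is the one from compound 1 to compound 2, where a hydrogen replaced the ethyl on the oxygen of the chain and the number rose sharply.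

Compound 4 `CC(C)CCn1c(N2CCN(C)CC2)nc2ccccc21` has not been measured. Compared with compound 2 it carries isopropyl in place of hydroxy on a saturated chain carbon, two bonds along the chain from an aromatic nitrogen. This removes the hydroxy altogether and puts a branched carbon chain in its place, so the chain of compound 4 again ends without an oxygen-bound hydrogen, as it does in compound 1 and compound 3. The step from compound 1 to compound 2 is the one that bears on this change, and it was large. A step of similar size is therefore expected in the opposite direction, back toward the numbers of compounds 1 and 3.

For compound 4 the number in this assay is estimated at 15 nM, within 4 nM to 60 nM, which means an expected step of a 27-fold lower number from compound 2 to compound 4 (1.44 log units; beyond the scatter).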

Compound 4, half-maximal inhibitory concentration: 1400 nM
Beside the measured number, compound 4's estimate is 93-fold (1.97 log units) below it, and the stated range ends below it.
By their numbers in this assay, from the lowest: compounds 3 and 1 (each within the scatter of the next); then compound 2; then compound 4.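

In this assay, this change shows that removing the oxygen-bound hydrogen is not enough to bring the number down: isopropyl in place of hydroxy, on a saturated chain carbon, two bonds along the chain from an aromatic nitrogen, gives a 3.4-fold higher number from compound 2 to compound 4 (0.53 log units; beyond the scatter) and so moves the number up, not down. Isopropyl in place of ethoxy at the same place gives a 140-fold higher number from compound 1 to compound 4 (2.15 log units; beyond the scatter) as a much larger step, so among these three chain ends the ethoxy of compound 1 stands lowest, the hydroxy of compound 2 in the middle, and the branched all-carbon end of compound 4 highest. No measurement beyond these numbers bears on the reason for this order.

The compounds shown do not separate the oxygen of the ethoxy from the size of the group that carries it, so a methoxy or a longer ether chain at this place could fall on either side. From the compounds shown here alone, an amine at the end of the chain is also open, as is whether the same order holds on the core of compound 3.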